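The source may hold more compounds than are shown below. What is called first, only, known or untested is meant among the compounds shown, and "the series" means these compounds.

Compound 1 `CNc1cc(Oc2ccc(NC(=O)Nc3ccccc3)cc2)ncn1` gives 6300 nM in an assay on isolated protein for inhibition of serine/threonine-protein kinase TNNI3K (Homo sapiens); on this read-out higher numbers stand for weaker inhibition and lower numbers for stronger inhibition.
Compound 2 `CNc1cc(Oc2ccc(NC(=O)Nc3cccc(C(C)(C)C)c3)cc2)ncn1` gives 40 nM in this assay.
Compound 3 `CCc1cccc(NC(=O)Nc2ccc(Oc3cc(NC)ncn3)cc2)c1` gives 200 nM in this assay.

Compound 3 stands second highest of the three numbers: compound 2 sits nearest, with a 5.0-fold higher number from compound 2 to compound 3 (0.70 log units; beyond the scatter), and compound 1 furthest, with a 32-fold lower number from compound 1 to compound 3 (1.50 log units; beyond the scatter). Compound 4 `CNc1cc(Oc2ccc(NC(=O)Nc3cccc(C(C)F)c3)cc2)ncn1` differs from compound 3 by fluoro in place of hydrogen on a saturated chain carbon bound to an aromatic carbon and a saturated chain carbon. Among the measured compounds shown here, no measured step introduces a fluoro at such a place, so the known steps bear on it only indirectly. Those steps all concern the group on the aromatic carbon: a 160-fold lower number from compound 1 to compound 2 (2.20 log units; beyond the scatter) and a 32-fold lower number from compound 1 to compound 3 (1.50 log units; beyond the scatter) show that a group on that carbon matters a great deal, while a 5.0-fold higher number from compound 2 to compound 3 (0.70 log units; beyond the scatter) shows that the choice between ethyl and tert-butyl shifts the number only modestly. A single fluoro on the chain keeps the ethyl in place, so in this assay a step no larger than the scatter is expected, in either direction, giving no change at the digits printed from compound 3 to compound 4 (within the scatter). Compound 4 is therefore estimated at 200 nM, within the range 70 nM to 600 nM.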

Compound 4, half-maximal inhibitory concentration: 79 nM
For compound 4 the middle estimate is 2.5-fold (0.40 log units) above the measured one, and the stated range covers the measured number.
By their numbers in this assay, from the lowest: compounds 2 and 4 (each within the scatter of the next); then compound 3; then compound 1.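

In this assay the chain carbon bound to the aromatic carbon proves responsive to the exchange of one hydrogen for fluoro, with a 2.5-fold lower number from compound 3 to compound 4 (0.40 log units; beyond the scatter) and so a step beyond the scatter where the earlier compounds had only shown changes of the whole group. The 1-fluoroethyl group, at an 80-fold lower number from compound 1 to compound 4 (1.90 log units; beyond the scatter) relative to hydrogen, also brings the compound level with the tert-butyl compound, since a 2.0-fold higher number from compound 2 to compound 4 (0.30 log units; within the scatter) leaves the two indistinguishable, which ethyl did not do. Nothing available accounts for why this one fluoro moves the number.

As far as these compounds go, whether a second fluoro on the same carbon, as in 1,1-difluoroethyl, would carry the step further remains open. So does what a hydroxyl or an amine would do in the fluoro's place, or a fluoro on a longer chain.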